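The source may report more compounds than this note shows. Statements on the series, on what has been measured and on what is new or still open speak of the compounds shown alone.

In a functional assay on ECa-109 cells for inhibition, with ECa-109 cell line (Homo sapiens) as the target, read by sulforhodamine B assay (on this read-out higher numbers stand for weaker inhibition and lower numbers for stronger inhibition), compound 1 `O=C1C(Nc2ccc(I)cc2)=CC(=O)c2c1nc1n2[C@H]2OC[C@@H](O)[C@H]2OC1` gives 2530 nM and compound 3 `O=C1C(Nc2ccc(Br)cc2)=CC(=O)c2c1nc1n2[C@H]2OC[C@@H](O)[C@H]2OC1` gives 1980 nM, so these two stand level within the scatter. Compound 2 `O=C1C(NC2CCCC2)=CC(=O)c2c1nc1n2[C@H]2OC[C@@H](O)[C@H]2OC1` reports only a limit, > 16000 nM. Against that limit, compound 3 stands clearly apart, as an at least 8.0-fold lower number from compound 2 to compound 3 (0.90 log units; beyond the scatter) shows. Compound 4 `CCc1ccc(NC2=CC(=O)c3c(nc4n3[C@H]3OC[C@@H](O)[C@H]3OC4)C2=O)cc1` carries ethyl in place of bromo on an aromatic carbon, para to a large group: ethyl in place of bromo on an aromatic carbon. The nearest measured change at that place is a 1.3-fold lower number from compound 1 to compound 3 (0.11 log units; within the scatter), whereas the far larger an at least 6.3-fold higher number from compound 1 to compound 2 (0.80 log units; beyond the scatter) replaces the whole 4-iodophenyl. A small change is therefore expected, with no step beyond the scatter, and the expected step is a 1.4-fold higher number from compound 3 to compound 4 (0.15 log units; within the scatter). Compound 4 is estimated at 2800 nM, with an expected range of 1000 nM to 8000 nM.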

Compound 4, half-maximal inhibitory concentration: > 4000 nM
Compound 4 gave a limit, no number (the forecaster's own chance of this, stated with the estimate: 5%); middle value at least 1.4-fold (0.15 log units) from the limit.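

Compound 4 reports only a limit: the limit of > 4000 nM in this assay, at which 1 of the 4 values shown sits. For the compounds shown here, with ethyl on this aromatic carbon the read-out gives an at least 2.0-fold higher number from compound 3 to compound 4 (0.30 log units; that floor lies within the scatter) and an at least 1.5-fold higher number from compound 1 to compound 4 (0.19 log units; that floor lies within the scatter), so the only non-halogen group here yields floors alone, and whether it truly parts from the level bromo and iodo pair stays undecided. The step between compound 2 and compound 4 joins two limits and cannot be read. The compounds shown leave open how a methoxy group, an amine or a carboxylic acid would read at this place.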